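Trifluoromethyl Variant of a Weak Nucleoside Series

This account rests on a few compounds, and the source may have more. Where it says the series, first, only, none or still open, it means among the compounds named here.

Compound 3 `OC[C@H]1O[C@@H](n2cnc3c(NCc4ccccc4OC(F)F)ncnc32)[C@H](O)[C@@H]1O` was examined in a functional assay on K562 cells (Homo sapiens) for antiproliferative activity, with a stated time of 72 h; a lower number here means a stronger inhibitor, a higher number a weaker inhibitor. For compound 3 only a limit of the assay is recorded there, > 166000 nM. Two comparators share its core. Compound 1 `OC[C@H]1O[C@@H](n2cnc3c(NCc4ccc(Cl)cc4)ncnc32)[C@H](O)[C@@H]1O` gives 218000 nM in this assay. Compound 2 `COc1cccc(CNc2ncnc3c2ncn3[C@@H]2O[C@H](CO)[C@@H](O)[C@H]2O)c1` is likewise reported only as a limit in this assay, > 166000 nM. The step that the limit leaves unreadable from compound 1 to compound 3 therefore cannot be sized, and the same holds for a step that the limit leaves unreadable from compound 1 to compound 2 and for a step that the two limits leave unreadable from compound 2 to compound 3, because the limit of > 166000 nM in this assay, at which 2 of the 3 values shown sit, blocks any reading of these steps. The unmeasured compound 4 `OC[C@H]1O[C@@H](n2cnc3c(NCc4ccc(C(F)(F)F)cc4)ncnc32)[C@H](O)[C@@H]1O` differs from compound 3 in one place: 4-(trifluoromethyl)phenyl in place of 2-(difluoromethoxy)phenyl on a saturated chain carbon bound to a nitrogen on an aromatic ring. Among the compounds with values here, no measured step bears directly on this change, and the three measured compounds offer no readable step at all; the one numerical value, that of compound 1, sits close to the limit. Compound 4 is therefore expected to remain weak, with an estimated step that the limit leaves unreadable from compound 3 to compound 4 that cannot be told apart from no change. The estimate for compound 4 in this assay is 200000 nM, with a range from 100000 nM to 400000 nM.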

Compound 4, half-maximal inhibitory concentration: > 166000 nM
Compound 4 was reported as a limit; the forecaster's own chance of this, stated with the estimate: 55%; the middle value does not contradict the limit.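

Compound 4 also gives only a limit in this assay, > 166000 nM. No new step to compound 4 from compound 1, compound 2 or compound 3 can be read, because of this: the limit of > 166000 nM in this assay, at which 3 of the 4 values shown sit.

The compounds shown leave open whether changing the phenyl group on the shared core alters activity in this assay at all.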